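From a Lower Starting Point: Adding One Methyl

The compounds below may be only part of what the source reports. "The series", "measured", "known", "first", "only" and "open" are said of these compounds alone.

Two compounds have so far been measured in a functional assay on the whole organism (liver, strain Wistar) for inhibition, with Rattus norvegicus as the target, with a stated time of 3 h, at a dose of 3 mg/kg by the oral route; a higher number here means more inhibition at the dose given (going by the name of the read-out), a lower number less inhibition:
- compound 1, `O=[N+]([O-])c1cc(-c2nnc(-c3ccccc3)o2)cc(O)c1O`, giving 67.8%
- compound 2, `Cc1cc(C)[n+]([O-])c(Cl)c1-c1noc(-c2cc(O)c(O)c([N+](=O)[O-])c2)n1`, giving 13.9%

Compound 2 thus stands lowest of the two numbers; its nearest neighbour, compound 1, sits a long way above it, and that gap is well beyond the usual scatter of such measurements. Going by the values given here, no step between compounds differing in only one place has been measured, so nothing is yet known about how small changes move this read-out.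

Compound 3, `Cc1c(C)c(C)[n+]([O-])c(Cl)c1-c1noc(-c2cc(O)c(O)c([N+](=O)[O-])c2)n1`, is the next to be tested. It differs from compound 2 by methyl in place of hydrogen on an aromatic carbon: a methyl group enters where a hydrogen leaves, on the six-membered aromatic ring that carries one nitrogen, with the rest of the shared core untouched. Among the compounds with values here, with no measured step of this kind to lean on, the expectation for the change from compound 2 to compound 3 is modest: a number 4.1 percentage points higher from compound 2 to compound 3 (within the scatter), that is, no movement beyond the scatter. Compound 3 is therefore estimated to show 18%, most likely between 3% and 40%.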

Compound 3, a percentage reported as inhibition, in the whole organism at one dose (the size of the read-out at that dose, not a potency): 7.9%
Compound 3: the middle estimate sits 10.1 percentage points above what was measured; the measured number falls inside the stated range.
By their numbers in this assay, from the lowest: compounds 3 and 2 (each within the scatter of the next); then compound 1.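

Swapping hydrogen for methyl gives a number 6 percentage points lower from compound 2 to compound 3 (within the scatter) in this assay and is the first single change that can be read here. At this aromatic carbon, ortho to two methyl groups and para to a chloro group, the added methyl therefore moves the number by no more than repeated measurements would. Nothing measured here offers an explanation for this result.

From the compounds shown here alone, whether a different group on this carbon, such as an ethyl chain, a methoxy group or an amine, would move the number beyond the scatter remains open. A single step also cannot show whether a methyl group in place of hydrogen would behave the same way on a different core.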